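The source may report more compounds than this note shows. Statements on the series, on what has been measured and on what is new or still open speak of the compounds shown alone.

Working notes on the series in a functional assay on HEK293 cells for antagonist activity at transient receptor potential cation channel subfamily V member 1 (Rattus norvegicus); a higher number here means a weaker inhibitor, a lower number a stronger inhibitor. Compound 1 `CC(C)c1ccc(NC(=O)N2CCN(c3ncccc3[N+](=O)[O-])CC2)cc1` in this assay gives 190 nM. Compound 2 `CC(C)c1ccc(NC(=O)N2CCN(c3ncccc3Cl)CC2)cc1` in this assay gives 11.5 nM. Within the data shown here, the only step measured so far, a 17-fold lower number from compound 1 to compound 2 (1.22 log units; beyond the scatter), is large and lies beyond the scatter; it concerns the group on the pyridine ring of the shared core. On the numbers shown compound 2 stands lowest of the two, and its one neighbour is compound 1 at the far end of that step.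

Compound 3 `O=C(Nc1ccc(Cl)cc1)N1CCN(c2ncccc2Cl)CC1` differs from compound 2 by chloro in place of isopropyl on an aromatic carbon. This exchange sits on the other aromatic ring, the one carrying the urea nitrogen, para to a large group. Among the measured compounds shown here, the measured step between compound 1 and compound 2 does not touch this ring, so no measured step bears directly on the change; what that ring tolerates is not yet reported in this assay. The expectation is therefore cautious: no step beyond the scatter, with some room for a modest rise in the number. For compound 3 the estimated value in this assay is 25 nM, with a range of 8 nM to 80 nM. The step this estimate implies is a 2.2-fold higher number from compound 2 to compound 3 (0.34 log units; beyond the scatter), expected rather than measured.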

Compound 3, half-maximal inhibitory concentration: 655 nM
The estimate for compound 3 lay 26-fold (1.42 log units) below the measured number; the whole stated range lies below it.
By their numbers in this assay, from the lowest: compound 2; then compound 1; then compound 3.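

In this assay, the aromatic carbon para to a large group proves highly sensitive: chloro in place of isopropyl gives a 57-fold higher number from compound 2 to compound 3 (1.76 log units; beyond the scatter), a large step. Among these compounds, the only earlier step, a 17-fold lower number from compound 1 to compound 2 (1.22 log units; beyond the scatter), concerned a different place on the shared core, so the series now has a large step at each of two separate places, and this second place can no longer be treated as untested. The exchange leaves the counts of hydrogen-bond donors, hydrogen-bond acceptors and net charge unchanged and replaces 3 heavy carbon atoms with 1 chlorine, but no measurement shown gives a reason for the rise in the number.

Going by these compounds, it remains open whether the low number of compound 2 is particular to isopropyl or is shared by other groups at this position, such as tert-butyl, trifluoromethyl, methoxy or a longer alkyl chain. Also open, on these data alone, is whether the step from nitro to chloro on the shared core keeps its size when chloro stands in place of isopropyl.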